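Trimming One Methoxy Group on a Shared Core

This account rests on a few compounds, and the source may have more. Where it says the series, first, only, none or still open, it means among the compounds named here.

Compound 1 `COc1ccc(-c2cc(/C=C/C(=O)c3ccc(N)cc3)[nH]n2)cc1`: 55500 nM
Compound 2 `COc1cc(-c2cc(/C=C/C(=O)c3ccc(N)cc3)[nH]n2)cc(OC)c1OC`: 47500 nM

Two compounds share the same core and differ only in how many methoxy groups sit on one aromatic ring. In a functional assay on MDA-MB-231 cells (Homo sapiens) for inhibition, read by sulforhodamine B assay, with a stated time of 48 h (on this read-out lower numbers stand for higher toxicity in this test and higher numbers for lower toxicity in this test), compound 1 gives 55500 nM, and compound 2 gives 47500 nM. On the numbers shown, compound 2 stands at the lower of the two, but its gap to compound 1 lies within the usual scatter, so the two cannot be told apart.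

Compound 3 `COc1ccc(-c2cc(/C=C/C(=O)c3ccc(N)cc3)[nH]n2)cc1OC` has not been measured in this assay. It differs from compound 2 by hydrogen in place of methoxy on an aromatic carbon, ortho to a methoxy group and meta to a large group. Among the measured compounds shown here, no step between measured compounds exists to lean on. Because compound 1 gives 55500 nM and compound 2 gives 47500 nM, within scatter of each other, no step beyond the scatter is expected, and the estimated step is a 1.1-fold higher number from compound 2 to compound 3 (0.02 log units; within the scatter). Compound 3 is expected to give about 50000 nM, with a range from 20000 nM to 120000 nM.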

Compound 3, concentration lethal to 50% of the cells: 53900 nM
For compound 3 the middle estimate is 1.1-fold (0.03 log units) below the measured one; the range from low to high includes it.
By their numbers in this assay, from the lowest: compounds 2, 3 and 1 (each within the scatter of the next).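

Compound 3 links both earlier compounds by single changes, so the effect of one methoxy group on this ring can now be read directly, which the pair of compounds 1 and 2 did not allow. In this assay, hydrogen in place of the methoxy group that is ortho to a methoxy group and meta to a large group gives a 1.1-fold higher number from compound 2 to compound 3 (0.05 log units; within the scatter), while the other single swap, methoxy in place of hydrogen on an aromatic carbon, gives a 1.0-fold lower number from compound 1 to compound 3 (0.01 log units; within the scatter), so neither change separates its pair in this test. No supporting measurement is available to explain this result.

Going by these compounds, it remains open whether a hydroxyl group, a fluorine atom or a longer alkoxy chain in place of methoxy on this ring would give a step beyond the scatter. On these data alone, the outcome of removing every methoxy group from this ring also remains open.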